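Thiourea amides on a shared core: tolerance on Huh-7 cells

The source may hold more compounds than are shown below. What is called first, only, known or untested is meant among the compounds shown, and "the series" means these compounds.

Measured compounds:
- Compound 1, `O=C(NC(=S)N1CCc2c(OCCCCCOc3ccc(Cl)cc3)cccc21)c1cccc([N+](=O)[O-])c1`: in an ADME assay on Huh-7 cells (Homo sapiens) for cytotoxicity (a higher number here means that more compound is tolerated, a lower number that less compound is tolerated), compound 1 gives 12100 nM.
- Compound 2, `CC(C)(C)c1ccc(C(=O)NC(=S)N2CCc3c(OCCCCCOc4ccc(Cl)cc4)cccc32)cc1`: in this assay compound 2 reaches only the assay limit of > 50000 nM.
- Compound 3, `O=C(NC(=S)N1CCc2c(OCCCCCOc3ccc(Cl)cc3)cccc21)c1ccc2ccccc2c1`: in this assay compound 3 likewise reaches only the assay limit of > 50000 nM.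

Compound 3 therefore stands at the top of what this series shows, at a limit and not a number, which is the state described by the limit of > 50000 nM in this assay, at which 2 of the 3 values shown sit. The next compound, compound 4, `O=C(NC(=S)N1CCc2c(OCCCCCOc3ccc(Cl)cc3)cccc21)c1ccco1`, differs from compound 3 by furan-2-yl in place of naphthalen-2-yl on a carbonyl carbon. Within the data shown here, no measured step touches a furan-2-yl group. Among the measured compounds shown here, the steps that bear on the amide aryl are an at least 4.1-fold higher number from compound 1 to compound 2 (0.61 log units; beyond the scatter) and an at least 4.1-fold higher number from compound 1 to compound 3 (0.61 log units; beyond the scatter), both rising from the nitrophenyl to a larger aryl, while a step that the two limits leave unreadable from compound 2 to compound 3. With compound 3 at the limit, a change toward a smaller heteroaryl is expected to give a small downward step, an at least 1.4-fold lower number from compound 3 to compound 4 (0.15 log units; that floor lies within the scatter), or none beyond the scatter. Compound 4 is thus expected near 35000 nM, within 12000 nM to 60000 nM.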

Compound 4, half-maximal cytotoxic concentration: 4620 nM
Estimate against measurement, compound 4: 7.6-fold (0.88 log units) above, outside the stated range (below it).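

In this assay, furan-2-yl in place of naphthalen-2-yl gives an at least 10-fold lower number from compound 3 to compound 4 (1.03 log units; beyond the scatter), and furan-2-yl in place of 4-(tert-butyl)phenyl gives an at least 10-fold lower number from compound 2 to compound 4 (1.03 log units; beyond the scatter). Furan-2-yl in place of 3-nitrophenyl still gives a 2.6-fold lower number from compound 1 to compound 4 (0.42 log units; beyond the scatter), so the group on this carbonyl carbon can move the number in both directions from compound 1, and compound 4 now marks the low end of the four compounds. The first two steps are floors and not full sizes, and they rest on a shared assay limit: the limit of > 50000 nM in this assay, at which 2 of the 4 values shown sit.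

The order of compound 2 and compound 3 remains unreadable, as both sit at that limit. The compounds shown do not separate the smaller ring from its ring oxygen, and a thiophen-2-yl or an unsubstituted phenyl on the carbonyl carbon would bear on that question.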